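A few compounds are considered here, and "the series" means these few. Any claim that something is new, unique, unknown or untested is made for them only; others in the source may bear on it.

Measured compounds:
Compound 1 `COc1ccc(-c2cnc(NC(=O)c3ccn[nH]3)n2C)cc1`; in a toxicity assay on THP-1 cells (Homo sapiens) for inhibition (on this read-out higher numbers stand for lower toxicity in this test and lower numbers for higher toxicity in this test), compound 1 gives > 100000 nM, which is a limit of the assay.
Compound 2 `COc1cccc(-c2cnc(NC(=O)c3ccc(F)cc3)n2C)c1`; compound 2 gives > 100000 nM, also a limit.
Compound 3 `COc1ccc(-c2cnc(NC(=O)c3cc(-c4ccccn4)n[nH]3)n2C)cc1`; compound 3 gives >= 50000 nM, again a limit.

Compound 1 thus stands at the limit of > 100000 nM in this assay, at which 2 of the 3 values shown sit, together with compound 2, while compound 3 sits at the limit of >= 50000 nM in this assay, at which 1 of the 3 values shown sits. Going by the values given here, the single measured step, a step that the two limits leave unreadable from compound 1 to compound 3, cannot be read, as both of its ends are limits. Compound 4 `COc1ccc(-c2cnc(NC(=O)c3ccc(Cl)cc3)n2C)cc1` differs from compound 1 by 4-chlorophenyl in place of 1H-pyrazol-5-yl on a carbonyl carbon. No measured step bears on this change; every compound shown has stayed at a limit without reaching a measurable toxicity. Compound 4 is expected to behave alike, with an estimate of 100000 nM (range 30000 nM to 300000 nM). The expected step of a number no higher from compound 1 to compound 4 (the limit leaves the size open) is therefore none beyond the scatter.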

Compound 4, half-maximal cytotoxic concentration: > 100000 nM
Compound 4: no number, only a limit; the forecaster's own chance of this, stated with the estimate: 80%; the middle value lies on the limit itself.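

Compound 1 and compound 4 both stand at a limit in this assay, so the step between them cannot be read. The compounds shown leave open which structural change, if any, would bring a measurable toxicity.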